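The source may hold more compounds than are shown below. What is called first, only, known or untested is meant among the compounds shown, and "the series" means these compounds.

Compound 3 `N#CC1=C(N)Oc2c(c3nc4ccccc4nc3c3ccccc23)C12C(=O)N(Cc1cnnn1-c1ccc(N)cc1)c1ccccc12` is one of three close analogues built on a shared core, differing only in the aryl group on an aromatic nitrogen. In a functional assay on A549 cells (Homo sapiens) for antiproliferative activity, read by MTT assay, with a stated time of 48 h (a lower number here means a stronger inhibitor, a higher number a weaker inhibitor), compound 3 gives only a limit, > 50000 nM. Compound 1 `N#CC1=C(N)Oc2c(c3nc4ccccc4nc3c3ccccc23)C12C(=O)N(Cc1cnnn1-c1cccc(Br)c1)c1ccccc12` likewise reaches only a limit in this assay, > 50000 nM. Compound 2 `CCOc1ccccc1-n1nncc1CN1C(=O)C2(C(C#N)=C(N)Oc3c2c2nc4ccccc4nc2c2ccccc32)c2ccccc21` also returns a limit in this assay, > 50000 nM. The steps a step that the two limits leave unreadable from compound 1 to compound 2, a step that the two limits leave unreadable from compound 1 to compound 3 and a step that the two limits leave unreadable from compound 2 to compound 3 therefore cannot be sized, since (the limit of > 50000 nM in this assay, at which 3 of the 3 values shown sit). Compound 4 `CC(=O)Nc1ccc(-n2nncc2CN2C(=O)C3(C(C#N)=C(N)Oc4c3c3nc5ccccc5nc3c3ccccc43)c3ccccc32)cc1` differs from compound 3 by acetyl in place of hydrogen on a nitrogen on an aromatic ring. Among the compounds with values here, none of the measured steps offers a readable size for this change, so no step beyond the scatter is expected. Compound 4 is expected to give 80000 nM, within 30000 nM to 200000 nM, meaning an expected step that the limit leaves unreadable from compound 3 to compound 4.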

Compound 4, half-maximal inhibitory concentration: > 50000 nM
Compound 4: a limit, no number; the forecaster's own chance of this, stated with the estimate: 85%; the middle value lies beyond the limit too.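

In this assay compound 4 gives > 50000 nM as a limit, so no step among compound 1, compound 2, compound 3 and compound 4 can be read: the limit of > 50000 nM in this assay, at which 4 of the 4 values shown sit.

As far as these compounds go, how these aryl groups on the shared core rank against one another stays open.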